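The compounds below may be only part of what the source reports. "The series", "measured", "known", "first", "only" and "open" are said of these compounds alone.

Compound 3 `C[C@@H](NC1CCN(CCCc2c[nH]c3ccc(-n4cnnc4)cc23)CC1)c1ccccc1` sits at the lowest number of the three measured in an assay on CHO cells for displacement of a labelled ligand from 5-hydroxytryptamine receptor 1D (Homo sapiens) (a lower number here means a stronger inhibitor, a higher number a weaker inhibitor), where compound 3 gives 0.4 nM. Its closest neighbour is compound 1 `CN(C1CCN(CCCc2c[nH]c3ccc(-n4cnnc4)cc23)CC1)S(=O)(=O)c1ccccc1`, which in this assay gives 1.5 nM, and the step of a 3.8-fold lower number from compound 1 to compound 3 (0.57 log units; beyond the scatter) is modest. Compound 2 `c1ccc(CNC2CCN(CCCc3c[nH]c4ccc(-n5cnnc5)cc34)CC2)cc1` lies furthest away, giving 4.6 nM in this assay, and the step of a 12-fold lower number from compound 2 to compound 3 (1.06 log units; beyond the scatter) is large. Compound 4 `c1ccc2c(c1)CCC2NCC1CCN(CCCc2c[nH]c3ccc(-n4cnnc4)cc23)CC1` is not yet measured. The change from compound 3 is ((2,3-dihydro-1H-inden-1-yl)amino)methyl in place of (1-phenylethyl)amino on a saturated ring carbon. All three measured steps alter the same saturated ring carbon, so all bear on it: a 3.1-fold higher number from compound 1 to compound 2 (0.49 log units; beyond the scatter) and a 3.8-fold lower number from compound 1 to compound 3 (0.57 log units; beyond the scatter) show that the group on this carbon moves the number by modest amounts, and a 12-fold lower number from compound 2 to compound 3 (1.06 log units; beyond the scatter) shows that a methyl on the chain carbon bound to the amine nitrogen and the aromatic carbon brings a large gain. Among the measured compounds shown here, compound 4 keeps a substituted carbon of that kind inside a five-membered ring but also inserts a methyl between the ring carbon and the amine nitrogen, a change no measured step covers. A modest move to a higher number is therefore expected, a 3.8-fold higher number from compound 3 to compound 4 (0.57 log units; beyond the scatter), with a wide range. For compound 4 in this assay the estimate is 1.5 nM, from 0.4 nM to 6 nM.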

Compound 4, half-maximal inhibitory concentration: 1.1 nM
Beside the measured number, compound 4's estimate is 1.4-fold (0.13 log units) above it; the range from low to high includes it.
By their numbers in this assay, from the lowest: compound 3; then compounds 4 and 1 (each within the scatter of the next); then compound 2.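

In this assay, ((2,3-dihydro-1H-inden-1-yl)amino)methyl on the saturated ring carbon gives up only a modest part of the (1-phenylethyl)amino result, a 2.8-fold higher number from compound 3 to compound 4 (0.44 log units; beyond the scatter), and still improves on benzylamino, a 4.2-fold lower number from compound 2 to compound 4 (0.62 log units; beyond the scatter). Against methyl(phenylsulfonyl)amino the reading is a 1.4-fold lower number from compound 1 to compound 4 (0.13 log units; within the scatter), so these two quite different groups on this carbon are not separated by this assay. No supporting data bear on why the steps have these sizes.

The step to compound 4 combines a five-membered ring with a longer link to the amine, and only ((1-phenylethyl)amino)methyl or (2,3-dihydro-1H-inden-1-yl)amino on the same carbon would separate the two contributions. As far as these compounds go, the entering group also carries no defined stereocentre, unlike the group it replaces, so the separate (R)- and (S)-forms of the dihydroindenyl group remain open.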